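The source may report more compounds than this note shows. Statements on the series, on what has been measured and on what is new or still open speak of the compounds shown alone.

Series notes, shared core with varied aryl on the amine nitrogen.

For the measured compounds named here, compound 2 `Fc1cccc(F)c1NCn1nc(-c2ccc3c(c2)OCCO3)oc1=S` gives 3320 nM in a functional assay, with a stated time of 6 min (a higher number here means a weaker inhibitor, a lower number a stronger inhibitor), the lowest of the three numbers so far. Compound 1 `CCOc1ccccc1NCn1nc(-c2ccc3c(c2)OCCO3)oc1=S` gives 5280 nM; the step of a 1.6-fold lower number from compound 1 to compound 2 (0.20 log units; within the scatter) is within the scatter, so the two are not separated. Compound 3 `S=c1oc(-c2ccc3c(c2)OCCO3)nn1CNc1cccc(Br)c1` gives 10800 nM; the steps of a 2.0-fold higher number from compound 1 to compound 3 (0.31 log units; beyond the scatter) and a 3.3-fold higher number from compound 2 to compound 3 (0.51 log units; beyond the scatter) both lie beyond the scatter, modest in size.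

Compound 4 `O=[N+]([O-])c1ccccc1NCn1nc(-c2ccc3c(c2)OCCO3)oc1=S` is not yet measured. The change from compound 2: 2-nitrophenyl in place of 2,6-difluorophenyl on an amine nitrogen. Both measured steps from compound 2 bear on it, since both also exchange the 2,6-difluorophenyl for another substituted phenyl on the amine nitrogen; the move to 2-ethoxyphenyl cost nothing beyond the scatter, the move to 3-bromophenyl cost a modest step. The 2-nitrophenyl is a further such exchange, so a step in the direction of a higher number is expected, of the size a 1.4-fold higher number from compound 2 to compound 4 (0.16 log units; within the scatter), and not beyond modest. Compound 4 is therefore estimated at 4800 nM in this assay, with a range of 2000 nM to 12000 nM.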

Compound 4, half-maximal inhibitory concentration: 10900 nM
Beside the measured number, compound 4's estimate is 2.3-fold (0.36 log units) below it, and the stated range covers the measured number.
By their numbers in this assay, from the lowest: compounds 2 and 1 (each within the scatter of the next); then compounds 3 and 4 (each within the scatter of the next).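

In this assay the exchange of 2,6-difluorophenyl for 2-nitrophenyl on the amine nitrogen gives a 3.3-fold higher number from compound 2 to compound 4 (0.52 log units; beyond the scatter), so a modest step at this position is not confined to the 3-bromophenyl group. The step of a 2.1-fold higher number from compound 1 to compound 4 (0.31 log units; beyond the scatter) separates 2-nitrophenyl from 2-ethoxyphenyl, so the nature of the group counts here and not only the numbering in its name. For the compounds shown here, with a 1.0-fold higher number from compound 3 to compound 4 (0.00 log units; within the scatter), 2-nitrophenyl and 3-bromophenyl are not separated, and across the four compounds no step at this position exceeds modest.

No measurement shown here speaks to the origin of these steps. From the compounds shown here alone, whether an unsubstituted phenyl, or a phenyl carrying an amine or a carboxylic acid, would move the number outside this modest span stays open.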